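Shortening the alkoxy chain on the shared core

The compounds below may be only part of what the source reports. "The series", "measured", "known", "first", "only" and "open" are said of these compounds alone.

Measured compounds and their maximal responses:
compound 1 `Oc1ccc(-c2nc3cc(C(F)(F)F)ccc3[nH]2)cc1`: 51.2%
compound 2 `CC(C)Oc1ccccc1-c1nc2cc([N+](=O)[O-])ccc2[nH]1`: 80.7%
compound 3 `COc1cc(-c2nc3cc(C(F)(F)F)ccc3[nH]2)ccc1O`: 99.6%

In a functional assay on aorta (Rattus norvegicus, strain Wistar) for inhibition, with a stated time of 60 min (on this read-out lower numbers stand for smaller maximal responses and higher numbers for larger maximal responses), compound 2 stands second highest of the three numbers. Its nearest neighbour is compound 3, whose maximal response lies higher by an amount beyond the scatter, and the furthest is compound 1, whose maximal response lies lower by an amount beyond the scatter.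

Going by the values given here, only one step between measured compounds that differ in a single place exists: a number 48.4 percentage points higher from compound 1 to compound 3 (beyond the scatter), a large rise for methoxy in place of hydrogen on an aromatic carbon.

Compound 4 `CCOc1ccccc1-c1nc2cc([N+](=O)[O-])ccc2[nH]1` differs from compound 2 by hydrogen in place of methyl on a saturated chain carbon bound to an oxygen on an aromatic ring and a saturated chain carbon. Among the compounds with values here, no measured step concerns the length of an alkoxy chain; the one step on record alters a substituent on an aromatic carbon and does not bear on this change. With nothing in the data pointing either way, compound 4 is expected to give about the same maximal response as compound 2, so that a number 1.7 percentage points lower from compound 2 to compound 4 (within the scatter) is expected to stay within the scatter. The estimate for compound 4 in this assay is 79%, with a range from 62% to 95%.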

Compound 4, largest response reached (Emax), in percent of the reference or control that the assay uses: 84.8%
Compound 4: the middle estimate sits 5.8 percentage points below what was measured; the range from low to high includes it.
By their numbers in this assay, from the lowest: compound 1; then compounds 2 and 4 (each within the scatter of the next); then compound 3.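

In this assay, going by these compounds alone, the swap of isopropoxy for ethoxy gives a number 4.1 percentage points higher from compound 2 to compound 4 (within the scatter) and is the first step on record that touches the alkoxy chain, so losing this methyl from a saturated chain carbon bound to an oxygen on an aromatic ring and a saturated chain carbon does not separate compound 2 from compound 4 on this read-out. Within the data shown here, the only earlier step, a number 48.4 percentage points higher from compound 1 to compound 3 (beyond the scatter), concerned a substituent on an aromatic carbon of a different core, and it left open whether a change in the chain would register at all; for this one pair, the answer is that it does not rise above the scatter. No measurement offered here gives any reason for this result.

As far as these compounds go, what a longer chain such as butoxy would give in place of the ethoxy remains open, as does the outcome of putting an amine at the end of the chain. From the compounds shown here alone, it is also open whether isopropoxy and ethoxy would stay within the scatter of each other on a core carrying trifluoromethyl, as compound 1 and compound 3 do.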